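This account rests on a few compounds, and the source may have more. Where it says the series, first, only, none or still open, it means among the compounds named here.

Measured in a functional assay on BT-483 cells (Homo sapiens) for cytotoxicity, read by MTT assay, with a stated time of 24 h; on this read-out lower numbers stand for stronger inhibition and higher numbers for weaker inhibition:
- compound 1 `CCNc1cc(-c2ccc(NC(=O)Nc3ccc(OC)cc3)cc2C)ccn1` gives 25800 nM
- compound 2 `CCNc1cc(-c2ccc(NC(=O)Nc3ccc(OC)cc3)cc2C(F)(F)F)ccn1` gives 17600 nM
- compound 3 `CCNc1cc(-c2ccc(NC(=O)Nc3cccc(Cl)c3)cc2F)ccn1` gives 18500 nM

All three values lie within the usual scatter of one another, so compound 3 with 18500 nM is not separated from compound 1 or compound 2. The next compound is compound 4 `CCNc1cc(-c2ccc(NC(=O)Nc3ccc(OC)cc3)cc2F)ccn1`, which has 4-methoxyphenyl in place of 3-chlorophenyl on an amide-type nitrogen. Among the compounds with values here, no measured step covers this exchange. Within the data shown here, the only step available, a 1.5-fold lower number from compound 1 to compound 2 (0.17 log units; within the scatter), puts trifluoromethyl in place of methyl on an aromatic carbon, a different change, and it stays within the scatter. Compound 1 at 25800 nM and compound 2 at 17600 nM already carry the 4-methoxyphenyl group and sit in the same range as compound 3. No step beyond the scatter is therefore expected in this assay, and no direction can be claimed. The estimated step is a 1.1-fold higher number from compound 3 to compound 4 (0.03 log units; within the scatter) and it stays within the scatter. For compound 4 the expected value is 20000 nM with an estimated range from 11000 nM to 36000 nM and the measurement itself is still to come.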

Compound 4, half-maximal inhibitory concentration: 19600 nM
For compound 4 the middle estimate is 1.0-fold (0.01 log units) above the measured one, and the stated range covers the measured number.
By their numbers in this assay, from the lowest: compounds 2, 3, 4 and 1 (each within the scatter of the next).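

In this assay, the exchange of 3-chlorophenyl for 4-methoxyphenyl on the amide-type nitrogen can now be read directly, and it stays within the scatter (a 1.1-fold higher number from compound 3 to compound 4 (0.03 log units; within the scatter)). Compound 4 also links the aromatic-carbon groups: fluoro in place of trifluoromethyl (a 1.1-fold higher number from compound 2 to compound 4 (0.05 log units; within the scatter)) and fluoro in place of methyl (a 1.3-fold lower number from compound 1 to compound 4 (0.12 log units; within the scatter)) both stay within the scatter, so fluoro, methyl and trifluoromethyl are not separated at that place in these compounds with 4-methoxyphenyl. No measurement is available that would explain these results.

The compounds shown leave open whether an amine or a carboxylic acid in place of fluoro on that aromatic carbon would give a step beyond the scatter. They also leave open whether a pyridyl group in place of 4-methoxyphenyl on the amide-type nitrogen would do so.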